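Ring Size of the Hydroxylated Amine and Histamine Binding

The compounds below may be only part of what the source reports. "The series", "measured", "known", "first", "only" and "open" are said of these compounds alone.

Measured so far:
compound 1 `CCN(CC)CCCOc1ccc2c(c1)C(=O)N(C)CC2`: 542 nM
compound 2 `CN1CCc2ccc(OCCCN3CCC(O)C3)cc2C1=O`: 112 nM

Among the measured compounds shown here, in an assay on cerebellum for displacement of a labelled ligand from histamine H1 receptor (Cavia porcellus), read by scintillation counting, with a stated time of 60 min (a higher number here means a weaker inhibitor, a lower number a stronger inhibitor), compound 2 gives the lowest of the two numbers; its nearest neighbour is compound 1, and the one measured step, a 4.8-fold lower number from compound 1 to compound 2 (0.68 log units; beyond the scatter), lies beyond the scatter. Compound 3 `CN1CCc2ccc(OCCCN3CCC(O)CC3)cc2C1=O` differs from compound 2 by 4-hydroxypiperidin-1-yl in place of 3-hydroxypyrrolidin-1-yl on a saturated chain carbon, three bonds along the chain from an oxygen on an aromatic ring. For the measured compounds named here, no measured step covers this ring enlargement, so the only bearing is that compound 2 already holds the hydroxylated ring amine; a step within the scatter is expected. For compound 3 the estimate is 100 nM, with a range of 35 nM to 320 nM, corresponding to an expected step of a 1.1-fold lower number from compound 2 to compound 3 (0.05 log units; within the scatter).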

Compound 3, inhibition constant: 35 nM
The estimate for compound 3 lay 2.9-fold (0.46 log units) above the measured number; measured number inside the range.
By their numbers in this assay, from the lowest: compound 3; then compound 2; then compound 1.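

In this assay, ring size matters at this place on the chain: 4-hydroxypiperidin-1-yl in place of 3-hydroxypyrrolidin-1-yl gives a 3.2-fold lower number from compound 2 to compound 3 (0.51 log units; beyond the scatter), so the two hydroxylated ring amines are not interchangeable. Measured against diethylamino, the six-membered ring gives a 15-fold lower number from compound 1 to compound 3 (1.19 log units; beyond the scatter), a larger step than the five-membered ring gave. Nothing available accounts for the difference between the two rings. The compounds shown leave open whether the hydroxyl group contributes at all, which an unsubstituted piperidine would address. They also leave open how a morpholine or a longer chain would fare.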